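A few compounds are considered here, and "the series" means these few. Any claim that something is new, unique, unknown or untested is made for them only; others in the source may bear on it.

Measured compounds:
Compound 1 `O=c1[nH]cnc2c1c(-c1cccs1)cn2[C@@H]1O[C@H](CO)[C@@H](O)[C@H]1O` — in a functional assay on HCT-116 cells (Homo sapiens), read by MTT assay, with a stated time of 72 h (a higher number here means a weaker inhibitor, a lower number a stronger inhibitor), compound 1 gives > 20000 nM, which is a limit of the assay rather than a number.
Compound 2 `Nc1nc2c(c(-c3cccs3)cn2[C@@H]2O[C@H](CO)[C@@H](O)[C@H]2O)c(=O)[nH]1` — in this assay compound 2 gives > 20000 nM, again a limit of the assay.

Compound 1 therefore stands only at a limit: its true potency is not pinned down by the numbers shown. Within the data shown here, the single measured step, a step that the two limits leave unreadable from compound 1 to compound 2, is the change of amino in place of hydrogen on an aromatic carbon. Both of its ends sit at the same limit, as shown by the limit of > 20000 nM in this assay, at which 2 of the 2 values shown sit, so the size of that step cannot be read.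

The compound still to be measured is compound 3 `O=c1[nH]cnc2c1c(-c1cc3ccccc3o1)cn2[C@@H]1O[C@H](CO)[C@@H](O)[C@H]1O`. It differs from compound 1 by 1-benzofuran-2-yl in place of thiophen-2-yl on an aromatic carbon. Among the measured compounds shown here, no measured step covers this change, and the one step available gives no size, so there is no basis to expect a step in this assay in any particular direction. As compound 1 is itself only a limit, a real gain would have to be substantial before a number appears. The estimate for compound 3 is 25000 nM, expected to lie between 8000 nM and 80000 nM. This corresponds to an expected step that the limit leaves unreadable from compound 1 to compound 3.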

Compound 3, half-maximal inhibitory concentration: > 20000 nM
Compound 3 gave a limit, no number (the forecaster's own chance of this, stated with the estimate: 75%); the middle value is on the limit's open side.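

The result for compound 3 is again a limit of the assay, like that of compound 1, so no size can be read for the change from thiophen-2-yl to 1-benzofuran-2-yl: the limit of > 20000 nM in this assay, at which 3 of the 3 values shown sit. The compounds shown leave open how potent any of them truly is, and whether either change to the shared core alters potency at all.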